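Fluoro on the Phenyl Ring of Thiourea Benzothiazoles

This account rests on a few compounds, and the source may have more. Where it says the series, first, only, none or still open, it means among the compounds named here.

Measured compounds:
compound 1 `Fc1ccc(NC(=S)Nc2nc3ccc(F)cc3s2)cc1` gives 34600 nM
compound 2 `S=C(Nc1ccccc1)Nc1nc2c(Cl)cccc2s1` gives 31800 nM
compound 3 `Fc1ccc2nc(NC(=S)Nc3ccccc3)sc2c1` gives 46600 nM

All three were tested in a functional assay on THP-1 cells (Homo sapiens) for cytotoxicity, read by MTT assay, with a stated time of 48 h; a lower number here means a stronger inhibitor, a higher number a weaker inhibitor. Compound 1 and compound 3 share a core and differ by one change: fluoro in place of hydrogen on an aromatic carbon. That change gave a 1.3-fold lower number from compound 3 to compound 1 (0.13 log units; within the scatter), a step within the usual scatter. The cores of compound 2 and compound 3 differ, and that difference is not broken down here; their values sit within the scatter of one another.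

Compound 4 `Fc1ccc(NC(=S)Nc2nc3c(Cl)cccc3s2)cc1` is not yet measured. It is related to compound 2 by fluoro in place of hydrogen on an aromatic carbon, the same change that relates compound 3 to compound 1, made at the same place. On that single earlier step, a small move is expected from compound 2 to compound 4, about a 1.1-fold lower number from compound 2 to compound 4 (0.04 log units; within the scatter). Compound 4 is therefore estimated at 29000 nM, between 14000 nM and 60000 nM.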

Compound 4, half-maximal inhibitory concentration: > 50000 nM
Compound 4: a limit, no number; the forecaster's own chance of this, stated with the estimate: 15%; middle value at least 1.7-fold (0.23 log units) away from the limit.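

In this assay, compound 4 gives > 50000 nM, which is a limit of the assay and not a number. The change from phenyl to 4-fluorophenyl therefore gives only a floor for the step, an at least 1.5-fold higher number from compound 2 to compound 4 (0.19 log units; that floor lies within the scatter). Set beside the earlier step, this neither shows that the change carries over from one core to the other nor shows that it behaves differently on each: the same change on two cores in this assay, a 1.3-fold lower number (0.13 log units; within the scatter) from compound 3 to compound 1 and an at least 1.5-fold higher number (0.19 log units; that floor lies within the scatter) from compound 2 to compound 4; the limit leaves it open whether they differ

The compounds shown leave open the true value of compound 4, and so the real size of this step. They also leave open what an amine or a carboxylic acid in place of the fluoro would do on either core.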